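A few compounds are considered here, and "the series" means these few. Any claim that something is new, unique, unknown or untested is made for them only; others in the source may bear on it.

Measured so far:
compound 1 `CC(C)c1ccc(Nc2ccc3c(OCCCN4CCN(C)CC4)cccc3n2)cc1`, in a functional assay on Hs-578T cells (Homo sapiens) for inhibition, read by sulforhodamine B assay, with a stated time of 48 h; on this read-out lower numbers stand for stronger inhibition of growth and higher numbers for weaker inhibition of growth: 16900 nM
compound 2 `CN1CCN(CCCOc2cccc3nc(Nc4cc(Cl)cc(Cl)c4)ccc23)CC1`, in this assay: 2500 nM

For the measured compounds named here, compound 2 holds the lower of the two numbers; the only measured step, a 6.8-fold lower number from compound 1 to compound 2 (0.83 log units; beyond the scatter), replaces the whole aryl group and lies beyond the scatter. Compound 3 `CN1CCN(CCCOc2cccc3nc(Nc4cccc(Cl)c4)ccc23)CC1` differs from compound 2 by hydrogen in place of chloro on an aromatic carbon. Going by the values given here, no measured step removes a single chloro, so the bearing of that step on this assay is only indirect: it shows that the aryl substitution pattern moves the number. A move part of the way back toward compound 1 is expected, a 2.0-fold higher number from compound 2 to compound 3 (0.30 log units; within the scatter). Compound 3 is estimated at 5000 nM, within 2000 nM to 13000 nM.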

Compound 3, concentration for 50% growth inhibition: 1830 nM
The estimate for compound 3 lay 2.7-fold (0.44 log units) above the measured number, and the stated range ends above it.
By their numbers in this assay, from the lowest: compounds 3 and 2 (each within the scatter of the next); then compound 1.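

In this assay, hydrogen in place of one chloro on the 3,5-dichlorophenyl group gives a 1.4-fold lower number from compound 2 to compound 3 (0.14 log units; within the scatter) and so leaves the number unchanged within the scatter: at this position, the second chloro is not needed to hold that level. The 3-chlorophenyl group alone keeps the separation from the 4-isopropylphenyl group, with a 9.2-fold lower number from compound 1 to compound 3 (0.97 log units; beyond the scatter) on that change. Nothing available explains either step.

The compounds shown leave open whether any chloro is needed, as the plain phenyl group is not among them. As far as these compounds go, how a methoxy or trifluoromethyl group would read at this position also remains open.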